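This account rests on a few compounds, and the source may have more. Where it says the series, first, only, none or still open, it means among the compounds named here.

Measured so far in a functional assay, read by Griess assay, with a stated time of 150 min, tested at 50 ug/mL; a lower number here means a weaker effect, a higher number a stronger effect of the compound at the concentration tested:
- compound 1 `O=S(=O)(CC1=NCCO1)c1c(-c2ccccc2)nn(-c2ccccc2)c1-c1ccccc1`: 54.5%
- compound 2 `O=S(=O)(CC1=NCCO1)c1n[nH]cc1-c1ccc(Cl)cc1`: "not active" (no number reported)
- compound 3 `COc1ccc(-c2nn(-c3ccccc3)c(-c3ccc(C)cc3)c2S(=O)(=O)CC2=NCCS2)cc1`: "not active" (no number reported)

Compound 3 stands without a single number in this assay; the same holds for compound 2, so only compound 1 carries a value. Among the compounds with values here, no step between two measured compounds differs in one place, so no measured step size is available.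

Compound 4 `COc1ccc(-c2nn(-c3ccccc3)c(-c3ccc(C)cc3)c2S(=O)(=O)CC2=NCCO2)cc1` is the next entry and differs from compound 3 by a group of 5 heavy atoms (3 carbon, 1 nitrogen, 1 oxygen; one five-membered non-aromatic ring with 2 hetero atoms) in place of a group of 5 heavy atoms (3 carbon, 1 nitrogen, 1 sulfur; one five-membered non-aromatic ring with 2 hetero atoms), on a saturated chain carbon bound to a sulfonyl sulfur. Compound 1, which carries the same entering group on the saturated chain carbon bound to a sulfonyl sulfur, gives 54.5% in this assay, whereas compound 2, with that group too, gives "not active" (no number reported). The expected step from compound 3 to compound 4 in this assay is therefore uncertain, with a modest gain the more likely direction. Compound 4 is estimated at 20% in this assay, with a range from 0% to 50%.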

Compound 4, a percentage reported as activity, at one concentration (the size of the read-out at that concentration, not a potency): 61.6%
Compound 4: middle estimate off by 41.6 percentage points, on the low side, outside the stated range (above it).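

Within the data shown here, compound 3 carries no single number, so no step to compound 4 can be read in this assay. On these data alone, the size of the effect of exchanging the sulfur-containing ring for the oxygen-containing ring stays open. No measurement shown here speaks to a cause.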